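This account rests on a few compounds, and the source may have more. Where it says the series, first, only, none or still open, it means among the compounds named here.

Working notes on the series in an ADME assay (liver, Mus musculus) for metabolic stability, using microsomes; on this read-out higher numbers stand for a longer-lived compound and lower numbers for a shorter-lived compound. Of the compounds shown here, two have numbers so far. Compound 1 `CCc1nc2ccc(Cl)cn2c1C(=O)NCc1ccc(-c2ccc(C)cc2)cc1` gives 0.677 h in this assay. Compound 2 `CCc1nc2cc(Cl)ccn2c1C(=O)NCc1ccc(-c2ccc[nH]2)cc1` gives 0.18 h in this assay and stands lowest of the two; the nearest number is that of compound 1, and the gap between the two values lies beyond the scatter of repeated measurements. Within the data shown here, the two compounds differ in more than one place, so no single step can be drawn from them.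

The next compound to be measured is compound 3 `CCc1nc2cc(Cl)ccn2c1C(=O)NCc1ccc(N2CC3CCCCC3C2)cc1`. It differs from compound 2 as follows: a group of 9 heavy atoms (8 carbon, 1 nitrogen; one five-membered non-aromatic ring with 1 hetero atom, one six-membered non-aromatic ring of carbon only) in place of a group of 5 heavy atoms (4 carbon, 1 nitrogen; one five-membered aromatic ring with 1 hetero atom), on an aromatic carbon. Among the measured compounds shown here, no pair of measured compounds shows this change, so nothing in the numbers so far points to a direction for it. The expectation for compound 3 is therefore kept close to compound 2, with a wide range on either side: the step of a 1.4-fold higher number from compound 2 to compound 3 (0.14 log units; within the scatter) is expected to stay within the scatter, in whichever direction it turns out. On that basis compound 3 is estimated at 0.25 h in this assay, with a range from 0.1 h to 0.7 h.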

Compound 3, half-life: 0.105 h
Compound 3: the middle estimate sits 2.4-fold (0.38 log units) above what was measured, within the range that was stated.
By their numbers in this assay, from the lowest: compounds 3 and 2 (each within the scatter of the next); then compound 1.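

Among these compounds, on the aromatic carbon para to a large group, putting the group of 9 heavy atoms, with its five-membered non-aromatic ring and its six-membered non-aromatic ring of carbon only, in place of 1H-pyrrol-2-yl gives a 1.7-fold lower number from compound 2 to compound 3 (0.23 log units; within the scatter) in this assay and is the first single-place step. At this position, then, an aromatic ring with a hydrogen-bond donor and a two-ring non-aromatic group with a hydrogen-bond acceptor and no donor are not told apart by this read-out, even though the exchange alters the ring type, the heavy-atom count and the donor and acceptor counts together. Among the compounds shown here, nothing measured so far accounts for this result, and this single step cannot separate those changes.

Still open, on these data alone, is what a morpholine, a phenyl ring or a carboxylic acid on this same aromatic carbon would give in this assay and whether any of them would move the number beyond the scatter from compound 2. Also open, as far as these compounds go, is whether the same exchange would stay within the scatter on the core of compound 1, which gives 0.677 h with its own substituents.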